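This account rests on a few compounds, and the source may have more. Where it says the series, first, only, none or still open, it means among the compounds named here.

Working notes on the series. Three measured compounds share one core and differ only in the group on an amine nitrogen in a ring. In an assay on CHO cells for displacement of a labelled ligand from 5-hydroxytryptamine receptor 1D (Homo sapiens) (on this read-out lower numbers stand for stronger inhibition and higher numbers for weaker inhibition), compound 1 `c1cc(CN2CCN(CCCc3c[nH]c4ccc(-n5cnnc5)cc34)CC2)ccn1` gives 0.6 nM, compound 2 `c1c[nH]c(CN2CCN(CCCc3c[nH]c4ccc(-n5cnnc5)cc34)CC2)n1` gives 1.6 nM and compound 3 `NC(=O)C(c1ccccc1)N1CCN(CCCc2c[nH]c3ccc(-n4cnnc4)cc23)CC1` gives 0.2 nM, the lowest of the three numbers: the step of a 3.0-fold lower number from compound 1 to compound 3 (0.48 log units; beyond the scatter) and the step of an 8.0-fold lower number from compound 2 to compound 3 (0.90 log units; beyond the scatter) both run downward to it, while a 2.7-fold higher number from compound 1 to compound 2 (0.43 log units; beyond the scatter) separates the two groups of compounds 1 and 2. Compound 4 `c1cnc(N2CCN(CCCc3c[nH]c4ccc(-n5cnnc5)cc34)CC2)nc1` continues from compound 3 with pyrimidin-2-yl in place of carbamoyl(phenyl)methyl on an amine nitrogen in a ring. All three measured steps concern this same position, and each of them is modest. Compound 4 carries an aromatic ring with no carbamoyl group, as compounds 1 and 2 do, so the expected direction in this assay is a higher number than compound 3, of a size comparable to the steps seen toward compounds 1 and 2; the expected step is a 7.5-fold higher number from compound 3 to compound 4 (0.88 log units; beyond the scatter). Compound 4 is therefore estimated at about 1.5 nM in this assay, within a range from 0.4 nM to 6 nM.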

Compound 4, half-maximal inhibitory concentration: 0.6 nM
Estimate against measurement, compound 4: 2.5-fold (0.40 log units) above, and the stated range covers the measured number.
By their numbers in this assay, from the lowest: compound 3; then compounds 1 and 4 (each within the scatter of the next); then compound 2.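

In this assay the position on the amine nitrogen in a ring does not need a saturated chain carbon between the ring and the aromatic group: pyrimidin-2-yl, bound directly, shows no change at the digits printed from compound 1 to compound 4 (within the scatter) against (pyridin-4-yl)methyl and a 2.7-fold lower number from compound 2 to compound 4 (0.43 log units; beyond the scatter) against (1H-imidazol-2-yl)methyl. Among these compounds, the same change still gives a 3.0-fold higher number from compound 3 to compound 4 (0.48 log units; beyond the scatter) and so leaves carbamoyl(phenyl)methyl, the only group here with a carbonyl, at the lowest number of the four compounds. No evidence is at hand on what lies behind these steps. The change from compound 1 to compound 4 alters both the aromatic ring and the methyl linker, so a pyrimidin-2-ylmethyl or a directly bound pyridin-4-yl group would be needed to separate the two. As far as these compounds go, it also stays open whether carbamoylmethyl or benzyl alone would keep the number of compound 3.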